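Swapping the Amide Nitrogen Substituent in a Phenoxyacetamide Series

The source may report more compounds than this note shows. Statements on the series, on what has been measured and on what is new or still open speak of the compounds shown alone.

Measured compounds:
compound 1 `CCN(Cc1cccn1C)C(=O)COc1ccc(C)cc1` with 21300 nM
compound 2 `Cc1ccc(OCC(=O)N(Cc2cccs2)c2ncccn2)cc1` with 3700 nM
compound 3 `CCN(Cc1ccco1)C(=O)COc1ccc(C)cc1` with 489 nM

In an assay on HEK293 cells for agonist activity at transient receptor potential cation channel subfamily M member 8 (Homo sapiens), read by fluorescence and calcium flux, with a stated time of 15 min (a lower number here means that less compound is needed, a higher number that more compound is needed for the effect), compound 2 stands second highest of the three numbers. Its nearest neighbour is compound 1, which gives a higher number, and the furthest is compound 3, which gives a lower number; both gaps lie beyond the scatter.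

Compound 4 `Cc1ccc(OCC(=O)N(CCO)Cc2cccs2)cc1` is not yet measured. Its difference from compound 2 is 2-hydroxyethyl in place of pyrimidin-2-yl on an amide-type nitrogen. The pyrimidin-2-yl leaves and the 2-hydroxyethyl enters on the amide-type nitrogen whose other neighbours are a carbonyl carbon and a saturated chain carbon.

Among the measured compounds shown here, only one measured step exists, a 44-fold lower number from compound 1 to compound 3 (1.64 log units; beyond the scatter), and it concerns the group on the saturated chain carbon bound to that nitrogen, not the substituent on the nitrogen itself. It therefore does not bear directly on the change to compound 4. Compounds 1 and 3 carry an ethyl on that nitrogen and span a wide range between them, so no clear direction emerges for the new substituent. The step in this assay from compound 2 is expected to be a 1.4-fold higher number from compound 2 to compound 4 (0.13 log units; within the scatter), small and uncertain in sign. Compound 4 is estimated at 5000 nM, within a range of 1200 nM to 20000 nM.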

Compound 4, half-maximal effective concentration: 900 nM
Compound 4: middle estimate off by 5.6-fold (0.74 log units), on the high side, and the stated range ends above it.
By their numbers in this assay, from the lowest: compounds 3 and 4 (each within the scatter of the next); then compound 2; then compound 1.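

In this assay, among the compounds shown here, putting 2-hydroxyethyl in place of pyrimidin-2-yl gives a 4.1-fold lower number from compound 2 to compound 4 (0.61 log units; beyond the scatter), the first measured change to the substituent on the amide-type nitrogen itself, whereas the earlier step concerned only the group on the saturated chain carbon bound to that nitrogen. This pair shows that the six-membered aromatic ring on this nitrogen is not required for the lower number, since a group with no ring and fewer heavy atoms takes its place and the number still falls beyond the scatter. However, the change removes the ring and adds a hydrogen-bond donor at once, so the pair cannot separate the two, and no measurement at hand explains the shift.

The compounds shown leave open whether the hydroxyl of compound 4 contributes at all, which a 2-methoxyethyl or a 2-aminoethyl group on the same nitrogen would help to test. They also leave open how the number responds to a longer chain such as 3-hydroxypropyl, or to a chain bearing a carboxylic acid, at this position.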